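A few compounds are considered here, and "the series" means these few. Any claim that something is new, unique, unknown or untested is made for them only; others in the source may bear on it.

Of the compounds shown here, two from this series have so far been tested in a functional assay on TE-8 cells (Homo sapiens) for cytotoxicity, read by WST assay, with a stated time of 48 h; a higher number here means a weaker inhibitor, a lower number a stronger inhibitor. Compound 1 `CC(C)CC(=O)[C@@H]1O[C@@]12C(=O)C=C(Cc1ccccc1)NC2=O` is built on a small ring-fused core and carries a benzyl group. In this assay compound 1 reaches only the limit of the test, > 100000 nM, so no number inside the measurable range exists for it. Compound 2 `CC(C)C[C@]1(O)NC(=O)[C@]2(OC(Cc3ccccc3)=CC2=O)[C@H]1O` has a differently arranged core and also carries a benzyl group. In this assay compound 2 likewise stops at the limit, > 100000 nM, which is a boundary of the test rather than a number. Compound 2 therefore stands at the edge of what could be measured, the shared limit (the limit of > 100000 nM in this assay, at which 2 of the 2 values shown sit), with no measurable potency on record. Compound 3 `CC1=CC(=O)[C@]2(O1)C(=O)N[C@@](O)(CC(C)C)[C@@H]2O` follows from compound 2 by one change: hydrogen in place of phenyl on a saturated chain carbon bound to a double-bonded ring carbon. For the measured compounds named here, no pair of measured compounds shows what this change does to activity, so no measured step can guide the forecast. Compound 3 is expected to remain at the limit, and the step of a number no higher from compound 2 to compound 3 (the limit leaves the size open) is estimated as none beyond the scatter. The estimate for compound 3 is 100000 nM, with a range from 30000 nM to 300000 nM.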

Compound 3, half-maximal inhibitory concentration: > 100000 nM
Compound 3: a limit, no number (the forecaster's own chance of this, stated with the estimate: 85%); the middle value lies on the limit itself.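

For the compounds shown here, compound 2 and compound 3 both stop at a limit of the test rather than at a number, so no step between them can be read in this assay. The compounds shown leave open what any change in structure does to activity in this assay, since none of them gives a number inside the measurable range: the limit of > 100000 nM in this assay, at which 3 of the 3 values shown sit.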